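The compounds below may be only part of what the source reports. "The series", "measured", "known", "first", "only" and "open" are said of these compounds alone.

Measured compounds in a functional assay on SK-BR-3 cells (Homo sapiens) for antiproliferative activity, read by MTT assay, with a stated time of 72 h; on this read-out lower numbers stand for stronger inhibition and higher numbers for weaker inhibition:

Compound 1 `C/C=C1/[C@H](O[C@@H]2O[C@H](CO)[C@@H](O)[C@H](O)[C@H]2O)OC=C(C(=O)OC)[C@H]1CC(=O)NCCC` — in this assay compound 1 gives > 20000 nM, a limit of the assay and not a number.
Compound 2 `C/C=C1/[C@H](O[C@@H]2O[C@H](COC(C)=O)[C@@H](OC(C)=O)[C@H](OC(C)=O)[C@H]2OC(C)=O)OC=C(C(=O)OC)[C@H]1CC(=O)OCC` — in this assay compound 2 gives > 15000 nM, again a limit.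
Compound 3 `C/C=C1/[C@H](O[C@@H]2O[C@H](COC(C)=O)[C@@H](OC(C)=O)[C@H](OC(C)=O)[C@H]2OC(C)=O)OC=C(C(=O)OC)[C@H]1CC(=O)SCCc1ccccc1` — in this assay compound 3 gives > 15000 nM, again a limit.

Compound 1 thus stands at a limit, as do the other two values; nothing in the series has yet produced a number. Going by the values given here, the one step between measured compounds, a step that the two limits leave unreadable from compound 2 to compound 3, runs between two limits, and its size cannot be read. Both ends sit at the limit of > 15000 nM in this assay, at which 2 of the 3 values shown sit, while compound 1 sits at the limit of > 20000 nM in this assay, at which 1 of the 3 values shown sits.

The unmeasured compound 4 `C/C=C1/[C@H](O[C@@H]2O[C@H](CO)[C@@H](O)[C@H](O)[C@H]2O)OC=C(C(=O)OC)[C@H]1CC(=O)OCCC` differs from compound 1 by propoxy in place of propylamino on a carbonyl carbon: the propylcarbamoyl arm becomes a propoxycarbonyl arm, the rest of the shared core unchanged. Among the compounds with values here, the only measured step concerning a change on a carbonyl carbon is unreadable, so no direction can be drawn from it; the expectation is that compound 4 also stays at a limit, with no step beyond the scatter.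

For compound 4 the estimate in this assay is 25000 nM, with a range from 10000 nM to 60000 nM. The step this estimate implies is expected to be a step that the limit leaves unreadable from compound 1 to compound 4.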

Compound 4, half-maximal inhibitory concentration: > 15000 nM
Compound 4 ended at the assay's limit (the forecaster's own chance of this, stated with the estimate: 85%); the middle value does not contradict the limit.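

Compound 1 and compound 4 both stand at limits in this assay, and the step between them, propoxy in place of propylamino on a carbonyl carbon, cannot be read. The compounds shown leave open whether any change at this carbonyl carbon gives a measurable value in this assay.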